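The source may report more compounds than this note shows. Statements on the series, on what has been measured and on what is new or still open speak of the compounds shown alone.

Measured so far in a functional assay on HL-60 cells (Homo sapiens) for antiproliferative activity, with a stated time of 72 h; a lower number here means a stronger inhibitor, a higher number a weaker inhibitor:

Compound 1 `Nc1ncnn2c([C@@H]3O[C@H](CO)[C@@H](O)[C@H]3O)cc(C#Cc3ccc(F)cc3)c12` gives > 100000 nM, which is a limit of the assay and not a number.
Compound 2 `Nc1ncnn2c([C@@H]3O[C@H](CO)[C@@H](O)[C@H]3O)cc(C#Cc3ccccc3)c12` gives > 100000 nM, again a limit.
Compound 3 `Nc1ncnn2c([C@@H]3O[C@H](CO)[C@@H](O)[C@H]3O)cc(-c3ccccc3F)c12` gives > 100000 nM, again a limit.

Compound 1 differs from compound 2 by fluoro in place of hydrogen on an aromatic carbon. The step that the two limits leave unreadable from compound 2 to compound 1 cannot be sized because of the limit of > 100000 nM in this assay, at which 3 of the 3 values shown sit. Compound 3 differs from compound 2 by 2-fluorophenyl in place of 2-phenylethynyl on an aromatic carbon; the steps a step that the two limits leave unreadable from compound 2 to compound 3 and a step that the two limits leave unreadable from compound 1 to compound 3 are likewise unreadable.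

Compound 4 `Nc1ncnn2c([C@@H]3O[C@H](CO)[C@@H](O)[C@H]3O)cc(-c3ccc(F)cc3F)c12` is not yet measured. It differs from compound 3 by fluoro in place of hydrogen on an aromatic carbon. This is the same kind of change as from compound 2 to compound 1, but the surroundings differ: in compound 4 the entering fluoro is meta to a fluoro group (1 heavy atom) and para to a large group, whereas in compound 1 it is only para to a large group. The earlier step is unreadable, so it gives no size to carry over. The step that the limit leaves unreadable from compound 3 to compound 4 is expected to be within scatter, since compound 3 is at the limit and the expectation is that compound 4 stays there too. Compound 4 is estimated at 200000 nM, within 50000 nM to 1000000 nM.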

Compound 4, half-maximal inhibitory concentration: 99300 nM
For compound 4 the middle estimate is 2.0-fold (0.30 log units) above the measured one; low and high end bracket the measured number.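

In this assay, within the data shown here, compound 4 gives 99300 nM, the only value shown that is a number. Compound 3 gives > 100000 nM, which is a limit of the assay and not a number. The data give a number no higher from compound 3 to compound 4 (the limit leaves the size open) and a number no higher from compound 2 to compound 4 (the limit leaves the size open) and a number no higher from compound 1 to compound 4 (the limit leaves the size open). The same change, fluoro in place of hydrogen on an aromatic carbon, therefore shows only that compound 4 reads as a number, while neither its size on the core of compound 3 nor its size on the core of compound 2 can be read, and nothing shows whether it carries from one core to the other, and the sizes of the other steps to compound 4 are equally open, because the comparisons rest on a limit: the limit of > 100000 nM in this assay, at which 3 of the 4 values shown sit.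

Going by these compounds, whether fluoro in place of hydrogen has a measurable size in either setting stays open, as does any reading of the 2,4-difluorophenyl group against the 2-phenylethynyl group. Also open, on these data alone, is how an amine or a carboxylic acid would read in this assay on the aromatic carbon that takes the entering fluoro in compound 4.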